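A few compounds are considered here, and "the series" means these few. Any claim that something is new, unique, unknown or untested is made for them only; others in the source may bear on it.

Measured so far, in a functional assay (L1210 cells) for inhibition, with Mus musculus as the target; a higher number here means a weaker inhibitor, a lower number a stronger inhibitor:
compound 1 `C#CCN(Cc1cc2c(O)nc(C)nc2cc1C)c1ccc(C(=O)N[C@@H](CCC(=O)O)C(=O)N(C)[C@@H](CCC(=O)O)C(=O)O)c(F)c1` gives 340 nM
compound 2 `C#CCN(Cc1cc2c(O)nc(C)nc2cc1C)c1ccc(C(=O)N[C@@H](CCC(=O)O)C(=O)N(CC#C)[C@@H](CCC(=O)O)C(=O)O)c(F)c1` gives 110 nM
compound 3 `C#CCN(Cc1cc2c(O)nc(C)nc2cc1C)c1ccc(C(=O)N[C@@H](CCC(=O)O)C(=O)N(C)[C@@H](CCC(=O)O)C(=O)O)cc1` gives 220 nM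

The change from compound 2 to compound 1 is hydrogen in place of ethynyl on a saturated chain carbon bound to an amide-type nitrogen; it gave a 3.1-fold higher number from compound 2 to compound 1 (0.49 log units; beyond the scatter). Between compound 1 and compound 3 the step is a 1.5-fold lower number from compound 1 to compound 3 (0.19 log units; within the scatter). The difference between the cores of compound 2 and compound 3 is not broken down here.

Compound 4 `Cc1nc(O)c2cc(CN(C)c3ccc(C(=O)N[C@@H](CCC(=O)O)C(=O)N(C)[C@@H](CCC(=O)O)C(=O)O)cc3)c(C)cc2n1` is not yet measured. It differs from compound 3 by hydrogen in place of ethynyl on a saturated chain carbon bound to a nitrogen on an aromatic ring. This is the same kind of change as that from compound 2 to compound 1, but not the same: there the carbon carrying the change is bound to an amide-type nitrogen, here to a nitrogen on an aromatic ring. One measured pair shows this kind of change, so the expectation rests on that pair alone and on the value of compound 3.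

For compound 4 the expected step in this assay is a 4.1-fold higher number from compound 3 to compound 4 (0.61 log units; beyond the scatter), estimated to be of a size similar to, or somewhat larger than, the earlier step of a 3.1-fold higher number from compound 2 to compound 1 (0.49 log units; beyond the scatter). Compound 4 is therefore expected to give about 900 nM, with a likely range from 300 nM to 2700 nM.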

Compound 4, half-maximal inhibitory concentration: 640 nM
Beside the measured number, compound 4's estimate is 1.4-fold (0.15 log units) above it; measured number inside the range.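

In this assay, the change from propargyl to methyl on the nitrogen on an aromatic ring gives a 2.9-fold higher number from compound 3 to compound 4 (0.46 log units; beyond the scatter), and it matches the earlier step at the amide-type nitrogen: the same change on two cores in this assay, a 3.1-fold higher number (0.49 log units; beyond the scatter) from compound 2 to compound 1 and a 2.9-fold higher number (0.46 log units; beyond the scatter) from compound 3 to compound 4, 1.1-fold (0.03 log units) apart, within the scatter of two such steps. Across these two cores, the change therefore carries over in direction and size, although the carbon carrying it is bound to a different kind of nitrogen and the fluoro group of compound 1 and compound 2 is absent from compound 3 and compound 4. Going by these compounds alone, this rests on only two steps and does not show why they match, nor how the change would read on other cores.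

On these data alone, it remains open whether an ethyl group or a longer chain at either nitrogen would fall in line with propargyl or with methyl. Also open, as far as these compounds go, is how the change at the nitrogen on an aromatic ring reads when the fluoro group is present.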